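Swapping Dibromophenyl for Dimethoxyphenyl: Expected Solubility

The source may hold more compounds than are shown below. What is called first, only, known or untested is meant among the compounds shown, and "the series" means these compounds.

Compound 1 `Cc1oc(-c2c(Br)cccc2Br)nc1CN1CCC(C(=O)NCCCN2C[C@H](C)C[C@H](C)C2)CC1` has been tested in a physicochemical assay for solubility, in phosphate buffer, measured as kinetic solubility, at pH 7.4 (a lower number here means a less soluble compound, a higher number a more soluble compound), where compound 1 gives 62.4 ug/mL. That is the only plain number among the measurements shown. Compound 2 `Cc1ccccc1-c1nc(CN2CCC(C(=O)NCCCN3CC4CCCC(C4)C3)CC2)c(C)o1` differs from compound 1 in more than one place. In this assay compound 2 reaches only a limit, > 71 ug/mL, so no number is known for it. One of the two values shown therefore sits at the limit of > 71 ug/mL in this assay, at which 1 of the 2 values shown sits.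

Compound 3 `COc1cccc(OC)c1-c1nc(CN2CCC(C(=O)NCCCN3C[C@H](C)C[C@H](C)C3)CC2)c(C)o1` has not yet been measured in this assay. It differs from compound 1 in one place: 2,6-dimethoxyphenyl in place of 2,6-dibromophenyl on an aromatic carbon. Going by the values given here, no measured pair isolates this change, so its effect can only be estimated; a step of modest size is expected, if anything upward, though a result within the usual scatter would not surprise. Compound 3 is expected to give 70 ug/mL, between 35 ug/mL and 140 ug/mL, which corresponds to an expected step of a 1.1-fold higher number from compound 1 to compound 3 (0.05 log units; within the scatter), with a fair chance that the assay reports only a limit.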

Compound 3, solubility: > 76 ug/mL
Compound 3 ended at the assay's limit (the forecaster's own chance of this, stated with the estimate: 40%); at least 1.0-fold (0.03 log units) between middle value and limit.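

Going by these compounds alone, this is the first measured pair that isolates a change on this aromatic carbon of the five-membered ring: 2,6-dimethoxyphenyl in place of 2,6-dibromophenyl gives an at least 1.2-fold higher number from compound 1 to compound 3 (0.08 log units; that floor lies within the scatter). In this assay compound 3 gives > 76 ug/mL as a limit, not a number. The swap removes both bromine atoms and brings in 2 hydrogen-bond acceptors, yet the printed floor of the step does not establish a real gain over compound 1, and it leaves any true gain unsized.

Going by these compounds, how far compound 3 really lies from compound 1 remains open, since only a floor is known for the step. Also open is how this position would respond to a phenyl ring carrying an amine or a carboxylic acid, as neither group appears among the compounds shown.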